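Urea-linked series: methyl to fluorine on the terminal phenyl

The source may report more compounds than this note shows. Statements on the series, on what has been measured and on what is new or still open speak of the compounds shown alone.

Compound 1 `Cc1ccc(NC(=O)Nc2nc(-c3cc4ccccc4o3)cs2)cc1` is the reference point of the series. In a physicochemical assay, with a stated time of 6 min (on this read-out higher numbers stand for weaker inhibition and lower numbers for stronger inhibition), compound 1 gives 500 nM, the lowest of the two numbers recorded. Compound 2 `COc1ccc(NC(=O)Nc2nc(-c3cc4cc([N+](=O)[O-])ccc4o3)cs2)cc1` gives 121000 nM in this assay, a gap to compound 1 beyond the scatter, though the two structures differ in more than one place. For compound 3 `O=C(Nc1ccc(F)cc1)Nc1nc(-c2cc3cc(Br)ccc3o2)cs1` this assay reports only a limit, > 200000 nM (the limit of > 200000 nM in this assay, at which 1 of the 3 values shown sits). Compound 4 `O=C(Nc1cccc(F)c1)Nc1nc(-c2cc3ccccc3o2)cs1` carries 3-fluorophenyl in place of 4-methylphenyl on an amide-type nitrogen. Among the measured compounds shown here, no single-point step of this kind has been measured here, so the direction rests on the spread seen across the series. A modest weakening is expected, with the step from compound 1 to compound 4 estimated at a 3.0-fold higher number from compound 1 to compound 4 (0.48 log units; beyond the scatter). Compound 4 is therefore expected to give about 1500 nM in this assay, within 300 nM to 10000 nM.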

Compound 4, half-maximal inhibitory concentration: 4520 nM
The estimate for compound 4 lay 3.0-fold (0.48 log units) below the measured number; the range from low to high includes it.
By their numbers in this assay, from the lowest: compound 1; then compound 4; then compound 2. At a limit, above all of these: compound 3.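

Replacing 4-methylphenyl with 3-fluorophenyl on the amide-type nitrogen, with the core held constant, gives a 9.0-fold higher number from compound 1 to compound 4 (0.96 log units; beyond the scatter) in this assay. This first single-place step shows that the read-out responds to this position, even though both groups count 7 heavy atoms. No measured property bears on the cause of this shift.

The change of substituent and the change in its place on the phenyl ring remain inseparable in the compounds shown. Going by these compounds, how an amine or a carboxylic acid on that phenyl ring would read also stays open.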